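This account rests on a few compounds, and the source may have more. Where it says the series, first, only, none or still open, it means among the compounds named here.

The two measured compounds share one core. Compound 1 is `COc1ccc([C@@H]2CCc3c(OC)cc(OC)cc3O2)cc1` and compound 2 is `COc1ccc([C@@H]2CCc3c(OC)cc(OC)cc3O2)c(OC)c1`, which carries one more methoxy on an aromatic carbon. In a functional assay on U-937 cells (Homo sapiens) for antiproliferative activity, read by WST assay, with a stated time of 48 h (a lower number here means a stronger inhibitor, a higher number a weaker inhibitor), compound 1 gives 21000 nM. In this assay compound 2 gives > 100000 nM, which is a limit of the assay and not a number. Compound 2 therefore stands as the weaker of the two, known only through that limit. The step of an at least 4.7-fold higher number from compound 1 to compound 2 (0.67 log units; beyond the scatter) shows that the added methoxy weakened the compound, and because of the limit of > 100000 nM in this assay, at which 1 of the 2 values shown sits, the size of this step can only be given as a lower bound.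

Compound 3 is `COc1ccc([C@@H]2CCc3c(OC)cc(OC)cc3O2)c(O)c1`. It differs from compound 2 by hydrogen in place of methyl on an oxygen on an aromatic ring, which read one bond further out is methoxy to hydroxy, on the very group whose arrival weakened compound 2. Within the data shown here, no measured step covers this exact change; the only one that bears on it is an at least 4.7-fold higher number from compound 1 to compound 2 (0.67 log units; beyond the scatter), and undoing part of that addition might lower the number somewhat, though probably not back to where compound 1 sits. Compound 3 is therefore expected near 70000 nM, between 20000 nM and 250000 nM. This corresponds to an expected step of an at least 1.4-fold lower number from compound 2 to compound 3 (0.15 log units; that floor lies within the scatter).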

Compound 3, half-maximal inhibitory concentration: 4300 nM
For compound 3 the middle estimate is 16-fold (1.21 log units) above the measured one; the measured number lies below the stated range.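

The methyl on this one oxygen decides the outcome at this position: in this assay, going from methoxy to hydroxy gives an at least 23-fold lower number from compound 2 to compound 3 (1.36 log units; beyond the scatter). Compared with plain hydrogen at the same place, hydroxy gives a 4.9-fold lower number from compound 1 to compound 3 (0.69 log units; beyond the scatter), so this position is not one where any added group weakens the compound, as the methoxy of compound 2 alone might have suggested; a small change in the group decides whether the number rises or falls relative to compound 1. The limit belongs to compound 2, so the step from methoxy to hydroxy can be read only as a lower bound, and the true gap may be wider: the limit of > 100000 nM in this assay, at which 1 of the 3 values shown sits.

Going by these compounds, whether an amine, a fluorine or an ethoxy at this place would behave more like the hydroxy of compound 3 or more like the methoxy of compound 2 remains open. Equally open, on these data alone, is what a hydroxy would do in place of any other methoxy on the shared core, and whether the gain seen here is special to this position.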